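The source may hold more compounds than are shown below. What is called first, only, known or untested is meant among the compounds shown, and "the series" means these compounds.

Measured in an assay on frontal cortex for displacement of a labelled ligand from corticotropin-releasing factor receptor 1 (Rattus norvegicus), with a stated time of 2 h; on this read-out lower numbers stand for stronger inhibition and higher numbers for weaker inhibition: compound 1 `COc1nc(C)c(Nc2nc(Cl)cn([C@H](COC(C)=O)C3CC3)c2=O)cc1C` gives 5.3 nM; compound 2 `COc1nc(C)c(Nc2nc(Cl)cn([C@H](COC(=O)c3cccnc3)C3CC3)c2=O)cc1C` gives 5.2 nM; compound 3 `COc1nc(C)c(Nc2nc(Cl)cn([C@H](COC(=O)Nc3cccc(C#N)c3)C3CC3)c2=O)cc1C` gives 1.3 nM.

Compound 3 holds the lowest of the three numbers in this assay, and both measured steps leading to it are beyond the scatter: a 4.1-fold lower number from compound 1 to compound 3 (0.61 log units; beyond the scatter) and a 4.0-fold lower number from compound 2 to compound 3 (0.60 log units; beyond the scatter). Compound 4 `CCCNC(=O)OC[C@H](C1CC1)n1cc(Cl)nc(Nc2cc(C)c(OC)nc2C)c1=O` differs from compound 3 by propyl in place of 3-cyanophenyl on an amide-type nitrogen. Among the compounds with values here, no measured step covers this exact change. The two steps just named show that the (3-cyanophenyl)amino group on the carbonyl carbon brought the gain over the methyl and pyridin-3-yl groups of compounds 1 and 2. Compound 4 keeps the carbamate link but drops the aromatic ring, so part of that gain is expected to be given back: the expected step is a 3.1-fold higher number from compound 3 to compound 4 (0.49 log units; beyond the scatter). Compound 4 is therefore estimated at 4 nM, within 1.5 nM to 12 nM.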

Compound 4, half-maximal inhibitory concentration: 10 nM
Compound 4: the middle estimate sits 2.5-fold (0.40 log units) below what was measured, within the range that was stated.
By their numbers in this assay, from the lowest: compound 3; then compounds 2, 1 and 4 (each within the scatter of the next).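

In this assay, the carbamate link alone does not carry the gain seen with compound 3: with propyl on the amide-type nitrogen, the result is a 7.7-fold higher number from compound 3 to compound 4 (0.89 log units; beyond the scatter). The other comparisons, a 1.9-fold higher number from compound 2 to compound 4 (0.28 log units; within the scatter) and a 1.9-fold higher number from compound 1 to compound 4 (0.28 log units; within the scatter), both lie within the scatter, so the 3-cyanophenyl group, not the carbamate link, sets compound 3 apart here. No measurement shown explains this difference.

Whether the benzene ring alone or its nitrile accounts for the gain stays open; a plain phenyl group on the same nitrogen would separate the two.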